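A few compounds are considered here, and "the series" means these few. Any claim that something is new, unique, unknown or untested is made for them only; others in the source may bear on it.

Compound 1 `CCN(CC)C(=O)c1ccc(NC(=O)C(C)(O)C(F)(F)F)cc1` in an assay on a protein complex (Cavia porcellus) with sulfonylurea receptors; K-ATP channels (Homo sapiens) as the target; on this read-out lower numbers stand for stronger inhibition and higher numbers for weaker inhibition: > 30000 nM, a limit of the assay.
Compound 2 `CC(O)(C(=O)Nc1ccc([C@@H](O)c2ccccc2)cc1)C(F)(F)F` in this assay: > 30000 nM, a limit of the assay.

Compound 2 stands at a limit in this assay, so its place among the numbers cannot be fixed more closely. The step to compound 3 `CC(O)(C(=O)Nc1ccc(S(=O)(=O)N2CCCC2)cc1)C(F)(F)F` changes one group: (pyrrolidin-1-yl)sulfonyl in place of hydroxy(phenyl)methyl on an aromatic carbon. For the measured compounds named here, the only measured step that could bear on it is a step that the two limits leave unreadable from compound 1 to compound 2, and it is unreadable because of the limit of > 30000 nM in this assay, at which 2 of the 2 values shown sit. Going by the values given here, no measured step therefore gives a size or a direction for the change from compound 2 to compound 3. With both values shown sitting at the same limit, compound 3 is expected to give again a limit rather than a number, and the step of a number no higher from compound 2 to compound 3 (the limit leaves the size open) is expected to be one of no readable size. Compound 3 is estimated at 30000 nM, within a range from 10000 nM to 100000 nM.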

Compound 3, half-maximal inhibitory concentration: 880 nM
The estimate for compound 3 lay 34-fold (1.53 log units) above the measured number; measured number below the stated range.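

In this assay, this place on the aromatic carbon turns out to matter: putting (pyrrolidin-1-yl)sulfonyl there in place of hydroxy(phenyl)methyl gives an at least 34-fold lower number from compound 2 to compound 3 (1.53 log units; beyond the scatter), and putting it in place of diethylcarbamoyl gives an at least 34-fold lower number from compound 1 to compound 3 (1.53 log units; beyond the scatter). Compound 3 is the first compound shown with a number rather than a limit, so a change in this one place, with the rest of the core held fixed, is enough to bring the read-out within the measurable range. Both steps fix only a smallest size, because compound 1 and compound 2 each stand at a limit: the limit of > 30000 nM in this assay, at which 2 of the 3 values shown sit.

The compounds shown do not tell whether the sulfonyl link or the five-membered ring carries the change. They also leave open how a piperidine ring or a dimethylamino group on the sulfonyl would read in this assay.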